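Replacing hydroxy with nitro in a small series

This account rests on a few compounds, and the source may have more. Where it says the series, first, only, none or still open, it means among the compounds named here.

Measured in a functional assay on HCT-116 cells (Homo sapiens) for antiproliferative activity, read by MTT assay, with a stated time of 48 h; a higher number here means a weaker inhibitor, a lower number a stronger inhibitor:
Compound 1 `COc1ccc(CN(C(=O)CSc2nc3ccccc3s2)c2cc(OC)c(OC)c(OC)c2)cc1`: 426 nM
Compound 2 `COc1ccc(CN(C(=O)CSc2nc3ccccc3s2)c2cc(OC)c(OC)c(OC)c2)cc1O`: 182 nM

Compound 2, at 182 nM, holds the lower of the two numbers, which makes it the stronger inhibitor of the pair. Compound 3 `COc1ccc(CN(C(=O)CSc2nc3ccccc3s2)c2cc(OC)c(OC)c(OC)c2)cc1[N+](=O)[O-]` carries nitro in place of hydroxy on an aromatic carbon, ortho to a methoxy group: nitro in place of hydroxy on an aromatic carbon. Going by the values given here, only one measured step bears on this change: a 2.3-fold lower number from compound 1 to compound 2 (0.37 log units; beyond the scatter). Among the compounds with values here, that modest step came with adding the hydroxy, so losing it may give part of the difference back, although no measurement yet shows what nitro does. The expected change in this assay is a modest one toward a higher number, a 1.6-fold higher number from compound 2 to compound 3 (0.22 log units; within the scatter). For compound 3 the estimated value is 300 nM, with an expected range of 100 nM to 900 nM.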

Compound 3, half-maximal inhibitory concentration: 1280 nM
Beside the measured number, compound 3's estimate is 4.3-fold (0.63 log units) below it; measured number above the stated range.
By their numbers in this assay, from the lowest: compound 2; then compound 1; then compound 3.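

Nitro and hydroxy do not act alike at this position in this assay: there is a 7.0-fold higher number from compound 2 to compound 3 (0.85 log units; beyond the scatter) when nitro replaces hydroxy. Nitro also falls short of plain hydrogen, with a 3.0-fold higher number from compound 1 to compound 3 (0.48 log units; beyond the scatter) as the evidence, so the change does more than lose what hydroxy gained. No measured evidence here accounts for this difference.

The compounds shown leave open how an amine or a fluorine atom at this position would compare, and so whether hydroxy is the only group here that improves on hydrogen.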